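Nucleoside series: benzofuranyl against phenyl on the shared core

The source may report more compounds than this note shows. Statements on the series, on what has been measured and on what is new or still open speak of the compounds shown alone.

The series is followed in a functional assay on HL-60 cells (Homo sapiens) for antiproliferative activity, read by XTT assay, with a stated time of 72 h; a lower number here means a stronger inhibitor, a higher number a weaker inhibitor. Among the measured compounds shown here, compound 3 `COc1ncnc2c1c(-c1cc3ccccc3o1)cn2[C@@H]1O[C@H](CO)[C@@H](O)[C@H]1O` is the only member with a numeric reading: in this assay compound 3 gives 4470 nM. Compound 1 `COc1ncnc2c1c(-c1ccccc1)cn2[C@@H]1O[C@H](CO)[C@@H](O)[C@H]1O` carries phenyl in place of 1-benzofuran-2-yl on an aromatic carbon. In this assay compound 1 gives > 20000 nM, a limit of the assay and not a number. The step of an at least 4.4-fold higher number from compound 3 to compound 1 (0.65 log units; beyond the scatter) is therefore at least modest, its full size unknown because of the limit of > 20000 nM in this assay, at which 2 of the 3 values shown sit. Compound 2 `O=c1[nH]cnc2c1c(-c1cc3ccccc3o1)cn2[C@@H]1O[C@H](CO)[C@@H](O)[C@H]1O` differs from compound 3 in its core; that difference is not broken down here. In this assay compound 2 gives > 20000 nM, again a limit of the assay. Compound 4 `O=c1[nH]cnc2c1c(-c1ccccc1)cn2[C@@H]1O[C@H](CO)[C@@H](O)[C@H]1O` is not yet measured and stands to compound 2 as compound 1 stands to compound 3, phenyl in place of 1-benzofuran-2-yl on an aromatic carbon, the same change at the same place. For compound 4 the expected step that the limit leaves unreadable from compound 2 to compound 4 rests on the matching step an at least 4.4-fold higher number from compound 3 to compound 1 (0.65 log units; beyond the scatter), which ran toward weaker inhibition from a starting point that already sits at the limit. Compound 4 is expected to give about 40000 nM in this assay, most probably reported only as a limit, within 15000 nM to 150000 nM.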

Compound 4, half-maximal inhibitory concentration: > 20000 nM
Compound 4 was reported as a limit; the forecaster's own chance of this, stated with the estimate: 85%; the middle value does not contradict the limit.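

In this assay, among the compounds shown here, compound 2 and compound 4 both stand at a limit of the assay and not at a number, so no step between them can be read: the limit of > 20000 nM in this assay, at which 3 of the 4 values shown sit.

Still open, as far as these compounds go, is whether phenyl in place of 1-benzofuran-2-yl changes the reading on the core of compound 2, and how far compound 2 and compound 4 lie past the limit.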